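A few compounds are considered here, and "the series" means these few. Any claim that something is new, unique, unknown or untested is made for them only; others in the source may bear on it.

Measured so far in a functional assay (aorta) with Rattus norvegicus as the target; a lower number here means that less compound is needed, a higher number that more compound is needed for the effect:
compound 1 `O=C1CCCN1[C@@H]1c2cc([N+](=O)[O-])ccc2OC(CF)(CF)[C@H]1O` gives 24 nM;
compound 2 `O=C1CCCN1[C@@H]1c2cc(C(F)(F)C(F)(F)F)ccc2OC(CF)(CF)[C@H]1O` gives 6.31 nM;
compound 3 `O=C1CCCCN1[C@@H]1c2cc([N+](=O)[O-])ccc2OC(CF)(CF)[C@H]1O` gives 2.75 nM.

Compound 4 `O=C1CCCCN1[C@@H]1c2cc(C(F)(F)C(F)(F)F)ccc2OC(CF)(CF)[C@H]1O` has not yet been measured. It differs from compound 3 by 1,1,2,2,2-pentafluoroethyl in place of nitro on an aromatic carbon. The same change appears once more among these compounds, from compound 1 to compound 2, where it made a 3.8-fold lower number from compound 1 to compound 2 (0.58 log units; beyond the scatter). The two cores on which the change is made differ by 2-oxopiperidin-1-yl in place of 2-oxopyrrolidin-1-yl on a saturated ring carbon, while the place of the change is described in the same words in both pairs, so it is the same change set on a different core. Compound 4 is expected to show a 3.1-fold lower number from compound 3 to compound 4 (0.49 log units; beyond the scatter) because that change gave a 3.8-fold lower number from compound 1 to compound 2 (0.58 log units; beyond the scatter) and compound 3 already stands at 2.75 nM, a low starting point from which a second gain may not carry over in full. Compound 4 is estimated at 0.9 nM, with a likely range from 0.3 nM to 3 nM.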

Compound 4, half-maximal effective concentration: 3.89 nM
For compound 4 the middle estimate is 4.3-fold (0.64 log units) below the measured one; the measured number lies above the stated range.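

In this assay, 1,1,2,2,2-pentafluoroethyl in place of nitro did not repeat its earlier effect on the core carrying 2-oxopiperidin-1-yl, giving a 1.4-fold higher number from compound 3 to compound 4 (0.15 log units; within the scatter): the same change on two cores in this assay, a 3.8-fold lower number (0.58 log units; beyond the scatter) from compound 1 to compound 2 and a 1.4-fold higher number (0.15 log units; within the scatter) from compound 3 to compound 4, 5.4-fold (0.73 log units) apart, beyond the scatter of two such steps. Likewise, 2-oxopiperidin-1-yl in place of 2-oxopyrrolidin-1-yl gave a smaller step on the pentafluoroethyl core, a 1.6-fold lower number from compound 2 to compound 4 (0.21 log units; within the scatter): the same change on two cores in this assay, an 8.7-fold lower number (0.94 log units; beyond the scatter) from compound 1 to compound 3 and a 1.6-fold lower number (0.21 log units; within the scatter) from compound 2 to compound 4, 5.4-fold (0.73 log units) apart, beyond the scatter of two such steps. The two changes therefore do not simply add up here, but both gaps rest on the same four compounds, so this is one observation, and it does not show why the steps differ or whether other cores behave this way.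

As far as these compounds go, it remains open whether a nitrile or a trifluoromethyl on that aromatic carbon would carry over between these cores any better.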